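Thiourea series: aryl change at the saturated ring carbon

A few compounds are considered here, and "the series" means these few. Any claim that something is new, unique, unknown or untested is made for them only; others in the source may bear on it.

Measured so far in a functional assay, with a stated time of 20 min, tested at 10 uM; on this read-out lower numbers stand for a weaker effect and higher numbers for a stronger effect at the one concentration tested:
compound 1 `COc1cc(/C=C/C(=O)C2=C(/C=C/c3ccc(O)c(OC)c3)NC(=O)NC2c2ccccc2O)ccc1O` gives 73.6%
compound 2 `COc1cc(/C=C/C(=O)C2=C(/C=C/c3ccc(O)c(OC)c3)NC(=S)NC2c2ccccc2)ccc1O` gives 26.5%
compound 3 `COc1cc(/C=C/C(=O)C2=C(/C=C/c3ccc(O)c(OC)c3)NC(=S)NC2c2ccc(C)cc2)ccc1O` gives 43.2%

Compound 3 stands second highest of the three numbers. Its nearest neighbour is compound 2, which sits lower, beyond the scatter, and the furthest is compound 1, which sits higher, again beyond the scatter. Among the compounds with values here, the one single-point step in the set, a number 16.7 percentage points higher from compound 2 to compound 3 (beyond the scatter), is modest and points upward.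

The next compound is compound 4 `COc1cc(/C=C/C(=O)C2=C(/C=C/c3ccc(O)c(OC)c3)NC(=S)NC2c2ccccc2O)ccc1O`, not yet measured in this assay. It differs from compound 3 as follows: 2-hydroxyphenyl in place of 4-methylphenyl on a saturated ring carbon. Within the data shown here, no measured step covers this exact change. The step from compound 2 to compound 3 concerns the same saturated ring carbon but a different group, so it bears only loosely. Compound 1 also carries the 2-hydroxyphenyl group, with a carbonyl rather than a thiocarbonyl on the shared core, and its number is the highest shown, while compound 2 and compound 3 with the thiocarbonyl sit lower; this is all the two pairs of values show.

On that basis compound 4 is expected to land near the middle of the set, with a number 4.8 percentage points higher from compound 3 to compound 4 (within the scatter) as a small step that may stay within the scatter. The estimate for compound 4 is 48%, within 28% to 70%.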

Compound 4, a percentage reported as activity, at one concentration (the size of the read-out at that concentration, not a potency): 60.2%
Estimate against measurement, compound 4: 12.2 percentage points below, within the range that was stated.
By their numbers in this assay, from the lowest: compound 2; then compound 3; then compound 4; then compound 1.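

In this assay the aryl group on the saturated ring carbon has a clear hold on the read-out: a number 33.7 percentage points higher from compound 2 to compound 4 (beyond the scatter) with a hydroxy group added to the phenyl ring, a large step, while a number 17 percentage points higher from compound 3 to compound 4 (beyond the scatter) with 2-hydroxyphenyl in place of 4-methylphenyl, a modest one. Within the data shown here, compound 4 also completes the first pair that shares the 2-hydroxyphenyl group and differs only at the carbonyl or thiocarbonyl of the shared core, where compound 4 with the thiocarbonyl gives 60.2% and compound 1 with the carbonyl gives 73.6% in this assay. No accompanying measurement explains why these numbers move as they do.

Still open, from the compounds shown here alone, is whether the gain belongs to the hydroxy group itself or would also appear with a methoxy, an amine or a carboxylic acid on the same phenyl ring. The compounds shown also leave unsettled how 4-hydroxyphenyl would compare with 2-hydroxyphenyl at this saturated ring carbon, and whether the thiocarbonyl and carbonyl cores would keep the same order with other aryl groups.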